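A few compounds are considered here, and "the series" means these few. Any claim that something is new, unique, unknown or untested is made for them only; others in the source may bear on it.

Compound 1 `O=C(O)c1csc([C@H]2CC[C@@H]3[C@@H](COc4ccc(F)cc4)[C@H](O)C[C@@H]3O2)n1` is the starting point. In a functional assay on CHO cells for agonist activity at prostaglandin E2 receptor EP2 subtype (Homo sapiens), read by HTRF and cAMP accumulation, with a stated time of 30 min (a higher number here means that more compound is needed for the effect, a lower number that less compound is needed), compound 1 gives 7 nM, the highest of the two numbers measured here. Compound 2 `O=C(O)c1csc([C@H]2CC[C@@H]3[C@@H](COc4cccc(OC(F)(F)F)c4)[C@H](O)C[C@@H]3O2)n1` gives 0.9 nM in this assay, a lower number that lies beyond the usual scatter. Compound 3 `O=C(O)c1csc([C@H]2CC[C@@H]3[C@@H](COc4ccccc4C(F)(F)F)[C@H](O)C[C@@H]3O2)n1` has not been measured; it differs from compound 1 by 2-(trifluoromethyl)phenyl in place of 4-fluorophenyl on an oxygen on a saturated carbon. Among the measured compounds shown here, no measured pair shows this exact change, so the expected step of a 1.4-fold lower number from compound 1 to compound 3 (0.15 log units; within the scatter) is a small move toward a lower number, possibly within the scatter. Compound 3 is therefore estimated at 5 nM, with a range from 1.5 nM to 20 nM.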

Compound 3, half-maximal effective concentration: 0.5 nM
Compound 3: middle estimate off by 10-fold (1.00 log units), on the high side; measured number below the stated range.
By their numbers in this assay, from the lowest: compounds 3 and 2 (each within the scatter of the next); then compound 1.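

Putting 2-(trifluoromethyl)phenyl in place of 4-fluorophenyl on the oxygen gives, in this assay, a 14-fold lower number from compound 1 to compound 3 (1.15 log units; beyond the scatter), a large step and the first that can be read directly here. With the shared core unchanged, the aromatic group on this oxygen alone can therefore shift the number substantially. Still open, as far as these compounds go, is whether that shift belongs to the trifluoromethyl group itself or to its place on the ring, and whether a methyl group or a nitrile on that ring would do the same. Nothing measured here gives a reason for the step.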